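The compounds below may be only part of what the source reports. "The series", "measured", "known", "first", "only" and "open" are said of these compounds alone.

Compound 3 (`COc1cc(-c2nn(-c3cccc(NC(=O)Nc4ccc(Cl)c(Cl)c4)c3)cc2-c2ccncc2)ccc1Cl`) stands among three measured compounds of which none gives a number in a functional assay on HT-29 cells (Homo sapiens) for inhibition, read by sulforhodamine B assay, with a stated time of 48 h; a higher number here means that more compound is tolerated, a lower number that less compound is tolerated. In this assay compound 3 gives only the limit > 50000 nM. Compound 2 (`COc1cc(-c2nn(-c3cccc(NC(=O)c4cccc(C(F)(F)F)c4)c3)cc2-c2ccncc2)ccc1Cl`) likewise gives only the limit > 50000 nM in this assay. Compound 1 (`O=C(Nc1cccc(-n2cc(-c3ccncc3)c(-c3ccc(Cl)c(O)c3)n2)c1)Nc1cccc(C(F)(F)F)c1`) gives only the limit > 32500 nM in this assay. Among the measured compounds shown here, the one step between neighbours that differ in a single place, a step that the two limits leave unreadable from compound 2 to compound 3, cannot be read, and of compound 1 and compound 3, which differ in two places, the two limits show nothing more.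

Compound 4 (`O=C(Nc1cccc(-n2cc(-c3ccncc3)c(-c3ccc(Cl)c(O)c3)n2)c1)Nc1ccc(Cl)c(Cl)c1`) differs from compound 3 by hydrogen in place of methyl on an oxygen on an aromatic ring. For the measured compounds named here, no measured step follows this change on its own, but compound 1 already carries the hydroxy group together with a urea and sits at the limit of > 32500 nM in this assay, at which 1 of the 3 values shown sits, and compound 3 with its methoxy group sits at the limit of > 50000 nM in this assay, at which 2 of the 3 values shown sit. Going by the values given here, from these limits no direction can be read, and no step in this assay beyond the scatter is expected from compound 3 to compound 4, so the expected step of a number no higher from compound 3 to compound 4 (the limit leaves the size open) is essentially none. Compound 4 is therefore estimated at 50000 nM, within a range from 20000 nM to 100000 nM, and most likely reported again only as a limit.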

Compound 4, concentration lethal to 50% of the cells: > 32500 nM
Compound 4 ended at the assay's limit; the forecaster's own chance of this, stated with the estimate: 85%; the middle value is on the limit's open side.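

In this assay compound 4 gives only a limit, > 32500 nM, so neither the step to it from compound 3 nor the step to it from compound 1 can be read. The compounds shown leave open whether methoxy to hydroxy, or either aryl group on the urea, changes the concentration lethal to the cells at all.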